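Moving the methyl group of compound 2

This account rests on a few compounds, and the source may have more. Where it says the series, first, only, none or still open, it means among the compounds named here.

Compound 1 `Cc1cc(OCCCS(C)(=O)=O)cc(C)c1-c1cccc(COc2ccc(OCC(=O)O)cc2)c1` gives 121 nM in a functional assay on CHO cells for agonist activity at Free fatty acid receptor 1 (Homo sapiens), read by fluorescence and calcium flux; on this read-out lower numbers stand for an effect already at smaller amounts and higher numbers for an effect only at larger amounts of compound. Compound 2 `Cc1cc(OCCCS(C)(=O)=O)cc(C)c1-c1cccc(COc2ccc(OC(C)C(=O)O)cc2)c1` gives 389 nM in this assay and stands highest of the two numbers shown; its only neighbour with a number lies at a 3.2-fold higher number from compound 1 to compound 2 (0.51 log units; beyond the scatter). Compound 3 `CCC(Oc1ccc(OCc2cccc(-c3c(C)cc(OCCCS(C)(=O)=O)cc3C)c2)cc1)C(=O)O` gives "not determined" (no result reported) in this assay, so no number is available for it.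

Compound 4 `Cc1cc(OCc2cccc(-c3c(C)cc(OCCCS(C)(=O)=O)cc3C)c2)ccc1OCC(=O)O` shares all atoms with compound 2, joined differently: 4-(carboxymethoxy)-3-methylphenyl in place of 4-(1-carboxyethoxy)phenyl on an oxygen on a saturated carbon. For the measured compounds named here, the only measured step that bears on this change is a 3.2-fold higher number from compound 1 to compound 2 (0.51 log units; beyond the scatter), where methyl in place of hydrogen on the saturated chain carbon moved the number beyond the scatter toward larger amounts. Going by the values given here, compound 4 undoes that substitution, which points back toward the number of compound 1; the methyl that enters on the aromatic ring has no measured precedent in this set, so its contribution is unknown and widens the range. For compound 4 a step of a 2.6-fold lower number from compound 2 to compound 4 (0.41 log units; beyond the scatter) is therefore expected. Compound 4 is estimated at 150 nM, within 50 nM to 450 nM.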

Compound 4, half-maximal effective concentration: 153 nM
Beside the measured number, compound 4's estimate is 1.0-fold (0.01 log units) below it; the measured number falls inside the stated range.
By their numbers in this assay, from the lowest: compounds 1 and 4 (each within the scatter of the next); then compound 2.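

Moving the methyl from the saturated chain carbon to the aromatic ring gives a 2.5-fold lower number from compound 2 to compound 4 (0.41 log units; beyond the scatter) in this assay, so the same atoms do not read alike at the two places. Methyl in place of hydrogen on an aromatic carbon gives a 1.3-fold higher number from compound 1 to compound 4 (0.10 log units; within the scatter) and stays within the scatter, whereas methyl in place of hydrogen on the saturated chain carbon gives a 3.2-fold higher number from compound 1 to compound 2 (0.51 log units; beyond the scatter) and lies beyond it. Nothing measured here accounts for this difference between the two places.

Open, as far as these compounds go, is whether a chlorine atom or a methoxy group in place of hydrogen on that aromatic carbon would also stay within the scatter of compound 1. The step to the ethyl group of compound 3 on the saturated chain carbon cannot be read, and compound 3 has no number.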